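A few compounds are considered here, and "the series" means these few. Any claim that something is new, unique, unknown or untested is made for them only; others in the source may bear on it.

Compound 1 `Nc1nnc(-c2ccccc2Oc2ccccc2F)o1`: 9.57 mg/kg
Compound 2 `Fc1ccccc1Oc1ccccc1-c1nnc(S)o1`: 43.1 mg/kg

In a functional assay on the whole organism with Mus musculus as the target, in the maximal electroshock model (on this read-out lower numbers stand for an effect already at smaller amounts and higher numbers for an effect only at larger amounts of compound), compound 1 gives 9.57 mg/kg, and compound 2 gives 43.1 mg/kg. Compound 2 thus stands at the higher of the two numbers, separated from compound 1 by the step of a 4.5-fold higher number from compound 1 to compound 2 (0.65 log units; beyond the scatter), which exchanges the group on the aromatic carbon of the shared core.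

Compound 3 `CSc1nnc(-c2ccccc2Oc2ccccc2F)o1` differs from compound 2 by methyl in place of hydrogen on a sulfur. Within the data shown here, no measured step concerns a methyl in place of hydrogen on a sulfur; the only step in hand, a 4.5-fold higher number from compound 1 to compound 2 (0.65 log units; beyond the scatter), changes the group on the aromatic carbon and does not bear directly on the present change. With nothing to indicate a direction, no step beyond the scatter is expected in this assay, and the estimated step of a 1.2-fold lower number from compound 2 to compound 3 (0.09 log units; within the scatter) reflects this. Compound 3 is therefore expected to give about 35 mg/kg in this assay, with a range from 12 mg/kg to 100 mg/kg.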

Compound 3, dose for half-maximal effect: > 100 mg/kg
Compound 3 gave a limit, no number (the forecaster's own chance of this, stated with the estimate: 10%); middle value at least 2.8-fold (0.45 log units) from the limit.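

For compound 3 the result in this assay is a limit and not a number: the limit of > 100 mg/kg in this assay, at which 1 of the 3 values shown sits. Methyl in place of hydrogen on the sulfur, a small change, still gives a step beyond the scatter, an at least 2.3-fold higher number from compound 2 to compound 3 (0.36 log units; beyond the scatter), which compound 1 and compound 2 alone could not show. Measured against the amino group, methylsulfanyl on the aromatic carbon gives a large step, an at least 10-fold higher number from compound 1 to compound 3 (1.01 log units; beyond the scatter), so among these three compounds the amino group gives the lowest number and the two sulfur groups both stand higher.

From the compounds shown here alone, how far compound 3 lies past its limit stays open, so both new steps give only a minimum size. Also open, going by these compounds, is whether a longer chain on the sulfur, such as ethyl, or a methylamino group in place of the amino group would follow the same direction.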